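A few compounds are considered here, and "the series" means these few. Any claim that something is new, unique, unknown or untested is made for them only; others in the source may bear on it.

Of the compounds shown here, three sharing one core have been tested in a functional assay on P388 cells (Mus musculus) for cytotoxicity (on this read-out lower numbers stand for stronger inhibition and higher numbers for weaker inhibition), and they differ only in the chain bound to an amide-type nitrogen in a ring. Compound 1 `CCN1C(=O)[C@@H](C)NC(=O)[C@@H]2Cc3ccc(OC)c(c3)Oc3ccc(cc3)C[C@@H](C(=O)N2C)N(C)C(=O)[C@H](C)NC(=O)[C@H](Cc2ccc(OC)cc2)N(C)C(=O)[C@@H]1C` gives 43.7 nM, compound 2 `CCCCCN1C(=O)[C@@H](C)NC(=O)[C@@H]2Cc3ccc(OC)c(c3)Oc3ccc(cc3)C[C@@H](C(=O)N2C)N(C)C(=O)[C@H](C)NC(=O)[C@H](Cc2ccc(OC)cc2)N(C)C(=O)[C@@H]1C` gives 21.4 nM and compound 3 `C/C=C/CN1C(=O)[C@@H](C)NC(=O)[C@@H]2Cc3ccc(OC)c(c3)Oc3ccc(cc3)C[C@@H](C(=O)N2C)N(C)C(=O)[C@H](C)NC(=O)[C@H](Cc2ccc(OC)cc2)N(C)C(=O)[C@@H]1C` gives 9.12 nM. Compound 3 has the lowest number of the three, and its gaps to both others lie beyond the scatter, so it is the strongest inhibitor so far.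

Compound 4 `COc1ccc(C[C@H]2C(=O)N[C@@H](C)C(=O)N(C)[C@H]3Cc4ccc(cc4)Oc4cc(ccc4OC)C[C@@H](C(=O)N[C@H](C)C(=O)N(CC=C(C)C)[C@@H](C)C(=O)N2C)N(C)C3=O)cc1` has 2-methylprop-1-en-1-yl in place of prop-1-en-1-yl on a saturated chain carbon bound to an amide-type nitrogen in a ring. Cut one bond further out, this is but-2-en-1-yl to 3-methylbut-2-en-1-yl.

The measured steps that bear on this change are a 2.0-fold lower number from compound 1 to compound 2 (0.31 log units; beyond the scatter), a 4.8-fold lower number from compound 1 to compound 3 (0.68 log units; beyond the scatter) and a 2.3-fold lower number from compound 2 to compound 3 (0.37 log units; beyond the scatter). All three are modest, so changes to this chain have so far moved the number only a little. None of them replaces one chain carrying a double bond with another, so they give a scale but no direction. The best starting point is therefore compound 3 at 9.12 nM, and no step beyond the scatter is expected in this assay.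

The expected change is a 1.2-fold higher number from compound 3 to compound 4 (0.08 log units; within the scatter). For compound 4 the estimated value is 11 nM, with an expected range of 4 nM to 28 nM.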

Compound 4, half-maximal inhibitory concentration: 6.92 nM
Compound 4: middle estimate off by 1.6-fold (0.20 log units), on the high side, and the stated range covers the measured number.
By their numbers in this assay, from the lowest: compounds 4 and 3 (each within the scatter of the next); then compound 2; then compound 1.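

In this assay, the change from but-2-en-1-yl to 3-methylbut-2-en-1-yl gives a 1.3-fold lower number from compound 3 to compound 4 (0.12 log units; within the scatter), so this first comparison of two chains that both carry a double bond does not separate them. The new chain also gives a 3.1-fold lower number from compound 2 to compound 4 (0.49 log units; beyond the scatter) and a 6.3-fold lower number from compound 1 to compound 4 (0.80 log units; beyond the scatter), which means that among these four compounds both chains with a double bond give lower numbers than both saturated chains, and no compound goes against this. Nothing measured on these compounds bears on why the numbers fall this way.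

As far as these compounds go, a saturated 3-methylbutyl chain would help to show whether the double bond or the branched end of the chain goes with the lower numbers, and that question stays open here. Also open, from the compounds shown here alone, is how this position would respond to a benzyl group, or to a chain ending in an amine or a carboxylic acid, and whether any such chain would move the number further than these steps do.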